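The compounds below may be only part of what the source reports. "The series", "measured", "known", "first", "only" and "open" are said of these compounds alone.

In an ADME assay on microsomes from liver (Rattus norvegicus) for metabolic stability, read by LC-MS, in the presence of a further agent that is not named here (on this read-out higher numbers stand for fast clearance and lower numbers for slow clearance), compound 3 (`Cc1ncc(C)n2nc(-c3ccc4nc(-c5ccco5)[nH]c4c3)nc12`) gives 26.3 mL.min-1.g-1, the highest of the three numbers, ahead of compound 2 (`Cc1ncc(C)n2nc(-c3ccc4nc(-c5ccccn5)[nH]c4c3)nc12`) at 11.1 mL.min-1.g-1 and compound 1 (`COc1cccnc1-c1nc2ccc(-c3nc4c(C)ncc(C)n4n3)cc2[nH]1`) at 5.4 mL.min-1.g-1. Compound 4 (`Cc1ncc(C)n2nc(-c3ccc4nc(-c5ccccc5)[nH]c4c3)nc12`) has phenyl in place of furan-2-yl on an aromatic carbon. Two measured steps change the same place, both modest: a 2.4-fold higher number from compound 2 to compound 3 (0.37 log units; beyond the scatter), with furan-2-yl in place of pyridin-2-yl, and a 4.9-fold higher number from compound 1 to compound 3 (0.69 log units; beyond the scatter), with furan-2-yl in place of 3-methoxypyridin-2-yl. Within the data shown here, no measured step brings in phenyl, so the direction remains open, and no change beyond the scatter is expected, the estimated step being a 1.1-fold higher number from compound 3 to compound 4 (0.06 log units; within the scatter). The estimate for compound 4 is 30 mL.min-1.g-1, with an expected range of 13 mL.min-1.g-1 to 60 mL.min-1.g-1.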

Compound 4, intrinsic clearance in microsomes: 27.4 mL.min-1.g-1
The estimate for compound 4 lay 1.1-fold (0.04 log units) above the measured number, within the range that was stated.
By their numbers in this assay, from the lowest: compound 1; then compound 2; then compounds 3 and 4 (each within the scatter of the next).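

In this assay, phenyl and furan-2-yl on this aromatic carbon between two ring nitrogen atoms give numbers that cannot be told apart (a 1.0-fold higher number from compound 3 to compound 4 (0.02 log units; within the scatter)), although phenyl has no hetero atom. Phenyl also stands apart from the pyridine-bearing groups, with pyridin-2-yl (a 2.5-fold higher number from compound 2 to compound 4 (0.39 log units; beyond the scatter)) and with 3-methoxypyridin-2-yl (a 5.1-fold higher number from compound 1 to compound 4 (0.71 log units; beyond the scatter)). Nothing shown here gives a reason for these steps. On these data alone, it remains open whether a methoxy group on the phenyl ring would give a number closer to that of compound 1. As far as these compounds go, how an amine on that ring would read also remains open.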